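Ester and acid pairs on two cinnamate cores

The source may hold more compounds than are shown below. What is called first, only, known or untested is meant among the compounds shown, and "the series" means these compounds.

Measured so far in a functional assay on EA.hy 926 cells (Homo sapiens) for cytotoxicity, read by MTT assay, with stated times of 24 h and 12 h; a higher number here means that more compound is needed for the effect, a lower number that less compound is needed:
compound 1 `COc1ccc(/C=C/C(=O)O)c(OC(=O)c2nc(C)c(C)nc2C)c1` gives 115000 nM
compound 2 `CCOC(=O)/C=C/c1ccc(OC)cc1OC(=O)c1nc(C)c(C)nc1C` gives 138000 nM
compound 3 `Cc1nc(C)c(C(=O)Oc2cccc(/C=C/C(=O)O)c2)nc1C` gives 24000 nM

Compound 3 stands at the lowest number of the three; compound 1 and compound 2 both lie beyond the scatter above it. The difference between the core of compound 3 and the core of compound 1 is not broken down here.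

One change is shared across the series. From compound 1 to compound 2 it is ethyl in place of hydrogen on an oxygen next to a carbonyl group, and it made a 1.2-fold higher number from compound 1 to compound 2 (0.08 log units; within the scatter) in this assay. The same change, (ethyl in place of hydrogen on an oxygen next to a carbonyl group), carries compound 3 to compound 4 `CCOC(=O)/C=C/c1cccc(OC(=O)c2nc(C)c(C)nc2C)c1`. Both changes sit on an oxygen next to a carbonyl group whose other neighbour is the carbonyl carbon, so the place is the same in each pair.

Because a 1.2-fold higher number from compound 1 to compound 2 (0.08 log units; within the scatter) stayed within the scatter, the step to compound 4 is expected to be small as well, about a 1.2-fold higher number from compound 3 to compound 4 (0.08 log units; within the scatter). Compound 4 is therefore estimated at 29000 nM in this assay, with a likely range from 12000 nM to 65000 nM.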

Compound 4, half-maximal effective concentration: 92600 nM
Estimate against measurement, compound 4: 3.2-fold (0.50 log units) below; measured number outside the range, above it.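

In this assay, ethyl in place of hydrogen on an oxygen next to a carbonyl group gives a 3.9-fold higher number from compound 3 to compound 4 (0.59 log units; beyond the scatter), whereas the same change gives a 1.2-fold higher number from compound 1 to compound 2 (0.08 log units; within the scatter). The size of the step therefore does not carry over from one core to the other: the same change on two cores in this assay, a 1.2-fold higher number (0.08 log units; within the scatter) from compound 1 to compound 2 and a 3.9-fold higher number (0.59 log units; beyond the scatter) from compound 3 to compound 4, 3.2-fold (0.51 log units) apart, beyond the scatter of two such steps

These two pairs show that the step depends on the core, but not which feature of the core is responsible, and they give no rule for any further core.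

The compounds shown leave open whether a longer chain on the same oxygen, or an amide in place of the ester, would track the small step on the core of compound 1 or the larger one on the core of compound 3.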